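The source may report more compounds than this note shows. Statements on the series, on what has been measured and on what is new or still open speak of the compounds shown alone.

Measured so far in an in vitro assay on CHOK cells for displacement of a labelled ligand from growth hormone secretagogue receptor type 1 (Homo sapiens); on this read-out higher numbers stand for weaker inhibition and lower numbers for stronger inhibition:
compound 1, `Nc1nc(N)c(-c2ccc(NCc3cnc4ccccc4c3)cc2)c(COCc2ccccc2)n1`, gives 130 nM
compound 2, `Nc1nc(N)c(-c2ccc(CNc3ccc([N+](=O)[O-])cc3)cc2)c(COCc2ccccc2)n1`, gives 0.8 nM
compound 3, `CCc1nc(N)nc(N)c1-c1ccc(CNc2ccc([N+](=O)[O-])cc2)cc1`, gives 9.2 nM

Compound 3 stands second highest of these three numbers. Among the compounds with values here, only one step is known that changes a single place: a 12-fold higher number from compound 2 to compound 3 (1.06 log units; beyond the scatter), where methyl replaces benzyloxy on a saturated chain carbon bound to an aromatic carbon. Compound 1 shows a higher number than compound 3, but the two differ in more than one place, so only their values can be set side by side.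

Compound 4, `CCc1nc(N)nc(N)c1-c1ccc(CNc2ccc(S(C)(=O)=O)cc2)cc1`, has not yet been measured. It differs from compound 3 by methylsulfonyl in place of nitro on an aromatic carbon. Within the data shown here, no measured step touches this group or this part of the molecule; the one known step, between compound 2 and compound 3, altered a different part of the core. The exchange keeps the count of hydrogen-bond acceptors and swaps a nitro for a methylsulfonyl, so a small step is expected, a 2.2-fold higher number from compound 3 to compound 4 (0.34 log units; beyond the scatter), toward a somewhat higher number in this assay. Compound 4 is therefore estimated at 20 nM, with a range from 5 nM to 80 nM.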

Compound 4, half-maximal inhibitory concentration: 9.8 nM
For compound 4 the middle estimate is 2.0-fold (0.31 log units) above the measured one; the range from low to high includes it.
By their numbers in this assay, from the lowest: compound 2; then compounds 3 and 4 (each within the scatter of the next); then compound 1.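

In this assay, within the data shown here, putting methylsulfonyl in place of nitro on this aromatic carbon, para to a large group, gives a 1.1-fold higher number from compound 3 to compound 4 (0.03 log units; within the scatter) and is the first measured change at this place. So, with the rest of compound 3 kept, nitro is not required for a value in this range: a group with one more heavy atom, different atoms and the same count of hydrogen-bond acceptors serves as well in this single pair. No measurement at hand explains why the two groups read alike.

On these data alone, it remains open whether an amine, a carboxylic acid or a plain hydrogen at this place would also stay in this range. As far as these compounds go, it is equally open whether methylsulfonyl would read like nitro on compound 2, which carries benzyloxy on its side chain.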